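Compound 3 to compound 4: a new group on the carbonyl

This account rests on a few compounds, and the source may have more. Where it says the series, first, only, none or still open, it means among the compounds named here.

In a functional assay on HL-60 cells (Homo sapiens) for antiproliferative activity, read by MTT assay, with a stated time of 24 h (on this read-out higher numbers stand for weaker inhibition and lower numbers for stronger inhibition), compound 1 (`CCCCc1oc2ccccc2c1C(=O)c1ccc(OCC(=O)N2CCOCC2)cc1`) stands at a limit, > 50000 nM, and not at a number. Compound 2 (`CCCCc1oc2ccccc2c1C(=O)c1ccc(OCCCC(=O)N2CCCC2)cc1`) gives 29900 nM and compound 3 (`CCCCc1oc2ccccc2c1C(=O)c1ccc(OCCCC(=O)N2CCOCC2)cc1`) gives 34100 nM, so compound 3 sits level with compound 2 within the scatter.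

The next change puts (1-phenylethyl)amino in place of morpholin-4-yl on a carbonyl carbon, which gives compound 4 (`CCCCc1oc2ccccc2c1C(=O)c1ccc(OCCCC(=O)N[C@@H](C)c2ccccc2)cc1`): (1-phenylethyl)amino in place of morpholin-4-yl on a carbonyl carbon. Within the data shown here, no measured compound carries (1-phenylethyl)amino or any other hydrogen-bond donor at this place, so the guidance is thin.

Two measured steps, an at least 1.6-fold lower number from compound 1 to compound 2 (0.22 log units; that floor lies within the scatter) and an at least 1.4-fold lower number from compound 1 to compound 3 (0.16 log units; that floor lies within the scatter), involve the chain that carries the carbonyl, and both are floors within the scatter. Among the measured compounds shown here, the one measured exchange on the carbonyl carbon alone, morpholin-4-yl in place of pyrrolidin-1-yl, is a 1.1-fold higher number from compound 2 to compound 3 (0.06 log units; within the scatter), and it is the ground for expecting no step beyond the scatter here. That precedent covers only a narrow change, so the range stays wide and a limit reading remains possible.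

The estimated step in this assay is a 1.4-fold lower number from compound 3 to compound 4 (0.15 log units; within the scatter) and points, if anywhere, to a lower number. For compound 4 the expected value is 24000 nM, with an estimated range of 9000 nM to 55000 nM.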

Compound 4, half-maximal inhibitory concentration: > 50000 nM
Compound 4: a limit, no number (the forecaster's own chance of this, stated with the estimate: 20%); middle value at least 2.0-fold (0.31 log units) from the limit.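

In this assay compound 4 gives a limit, > 50000 nM, and not a number. The steps of an at least 1.4-fold higher number from compound 3 to compound 4 (0.16 log units; that floor lies within the scatter) and an at least 1.6-fold higher number from compound 2 to compound 4 (0.22 log units; that floor lies within the scatter) are floors only, so (1-phenylethyl)amino on this carbonyl carbon, the first group shown with a hydrogen-bond donor at this place, shows no gain over morpholin-4-yl or pyrrolidin-1-yl, and the true size of either step cannot be read. Compound 2 and compound 3 give numbers on the same chain as compound 4, so a numbered reading on this chain does not hold for every group on the carbonyl carbon, and the window for telling these compounds apart is narrow: the limit of > 50000 nM in this assay, at which 2 of the 4 values shown sit.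

Open, going by these compounds, is whether the amide hydrogen, the phenyl ring or the defined stereocentre goes with the limit; methylamino, benzylamino and the mirror-image (1-phenylethyl)amino on the same carbonyl carbon would separate these. Also open, on these data alone, is whether a piperazine ring on this carbonyl carbon, a free carboxylic acid in place of the amide or a longer chain would give a step beyond the scatter from compound 2 or compound 3.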